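The source may report more compounds than this note shows. Statements on the series, on what has been measured and on what is new or still open speak of the compounds shown alone.

Working notes on the hydrazone series. Compound 1 `O=C(N/N=C/c1ccccc1)c1cccnc1` is the parent. In an ADME assay on HEL cells (Homo sapiens) for cytotoxicity, read by microscopy (a higher number here means that more compound is tolerated, a lower number that less compound is tolerated), compound 1 gives > 100 ug/mL, which is a limit of the assay rather than a number. Compound 2 `O=C(N/N=C/c1ccc(Cl)cc1)c1cccnc1` carries chloro in place of hydrogen on an aromatic carbon. In this assay compound 2 gives > 100 ug/mL, again a limit. The step that the two limits leave unreadable from compound 1 to compound 2 therefore has no readable size. Compound 2 thus stands at the limit of > 100 ug/mL in this assay, at which 2 of the 2 values shown sit, and no number fixes it inside the measured range.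

Compound 3 `O=C(N/N=C/c1ccc(Br)cc1)c1cccnc1` is the next change: bromo in place of chloro on an aromatic carbon. For the measured compounds named here, the only measured step that bears on it is a step that the two limits leave unreadable from compound 1 to compound 2, which the two limits leave unreadable, so no direction can be drawn from it and no step beyond the scatter is expected. Compound 3 is accordingly expected to sit near 100 ug/mL, most likely as a limit once more, with a range from 50 ug/mL to 200 ug/mL. The expected step is a number no higher from compound 2 to compound 3 (the limit leaves the size open).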

Compound 3, minimum cytotoxic concentration: > 100 ug/mL
Compound 3 was reported as a limit (the forecaster's own chance of this, stated with the estimate: 85%); the middle value lies on the limit itself.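

No step can be read among compound 1, compound 2 and compound 3 in this assay because each result is a limit of the assay: the limit of > 100 ug/mL in this assay, at which 3 of the 3 values shown sit.

The compounds shown leave open where the true tolerated concentrations lie and whether chloro or bromo in place of hydrogen changes them at all.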